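Halogen swap on the pyridine amide in a pyrazole series

The source may hold more compounds than are shown below. What is called first, only, known or untested is meant among the compounds shown, and "the series" means these compounds.

Compound 1 `O=C(Nc1cc(-c2ccccc2)[nH]n1)c1cccnc1F` is the reference point; in a functional assay on WM 266-4 cells (Homo sapiens) for antiproliferative activity, read by MTT assay, with a stated time of 48 h (a higher number here means a weaker inhibitor, a lower number a stronger inhibitor), compound 1 gives 3770 nM. Compound 2 `O=C(Nc1cc(-c2ccccc2)[nH]n1)c1cccnc1Cl` differs from it by chloro in place of fluoro on an aromatic carbon and in this assay compound 2 gives 6220 nM, a step of a 1.6-fold higher number from compound 1 to compound 2 (0.22 log units; within the scatter). Compound 3 `O=C(Nc1cc(-c2ccc(Br)cc2)[nH]n1)c1cccnc1F` carries a different core, the difference being (bromo in place of hydrogen on an aromatic carbon); in this assay compound 3 gives 4680 nM, a step of a 1.2-fold higher number from compound 1 to compound 3 (0.09 log units; within the scatter). Compound 4 `O=C(Nc1cc(-c2ccc(Br)cc2)[nH]n1)c1cccnc1Cl` is not yet measured and differs from compound 3 by chloro in place of fluoro on an aromatic carbon, the same change as that between compound 1 and compound 2, at the same place on the shared pyridine amide. Among the measured compounds shown here, the expected step is a 1.6-fold higher number from compound 3 to compound 4 (0.20 log units; within the scatter), because the one prior example of this change gave a 1.6-fold higher number from compound 1 to compound 2 (0.22 log units; within the scatter). For compound 4 the estimated value in this assay is 7400 nM, expected to lie between 3500 nM and 16000 nM.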

Compound 4, half-maximal inhibitory concentration: 6990 nM
Estimate against measurement, compound 4: 1.1-fold (0.02 log units) above; the range from low to high includes it.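

In this assay, chloro in place of fluoro gives a 1.5-fold higher number from compound 3 to compound 4 (0.17 log units; within the scatter), and the change carries across the two cores with no difference beyond the scatter: the same change on two cores in this assay, a 1.6-fold higher number (0.22 log units; within the scatter) from compound 1 to compound 2 and a 1.5-fold higher number (0.17 log units; within the scatter) from compound 3 to compound 4, 1.1-fold (0.04 log units) apart, within the scatter of two such steps. Bromo in place of hydrogen gives a 1.1-fold higher number from compound 2 to compound 4 (0.05 log units; within the scatter), and it likewise reads the same with fluoro or chloro on the pyridine amide: the same change on two cores in this assay, a 1.2-fold higher number (0.09 log units; within the scatter) from compound 1 to compound 3 and a 1.1-fold higher number (0.05 log units; within the scatter) from compound 2 to compound 4, 1.1-fold (0.04 log units) apart, within the scatter of two such steps. Among the compounds shown here, every step here lies within the scatter, so the four compounds show only that neither change moves the number measurably on these cores, not that either has a real effect that transfers, and not how either would behave on any other core.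

The compounds shown leave open whether an amine or a carboxylic acid in place of the chloro or the bromo would give a step beyond the scatter.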